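Pyrazole methylation and regiochemistry in a diaryl urea series

The source may report more compounds than this note shows. Statements on the series, on what has been measured and on what is new or still open speak of the compounds shown alone.

Compound 1 `CSc1cc(C)nc(SC)c1NC(=O)N(Cc1ccccc1)Cc1cccc(-c2cc[nH]n2)c1` gives 0.046 mg/kg in a functional assay on a cell-free system (plasma) with sterol O-acyltransferase, Soat (Rattus norvegicus) as the target; on this read-out lower numbers stand for an effect already at smaller amounts and higher numbers for an effect only at larger amounts of compound.
Compound 2 `CSc1cc(C)nc(SC)c1NC(=O)N(Cc1ccccc1)Cc1cccc(-c2ccn(C)n2)c1` gives only an assay limit in this assay, < 1 mg/kg.

Compound 2 thus sits at a limit, not at a number, so the step that the limit leaves unreadable from compound 1 to compound 2 stays unreadable, as the limit of < 1 mg/kg in this assay, at which 1 of the 2 values shown sits, shows. Compound 3 `CSc1cc(C)nc(SC)c1NC(=O)N(Cc1ccccc1)Cc1cccc(-c2ccnn2C)c1` carries 1-methyl-1H-pyrazol-5-yl in place of 1-methyl-1H-pyrazol-3-yl on an aromatic carbon. Among the compounds with values here, no measured step bears on this change, and the single measured step is unreadable, so no shift beyond the scatter in this assay is grounded either way. Compound 3 is therefore expected near 0.1 mg/kg, within 0.02 mg/kg to 0.8 mg/kg. The expected step is a step that the limit leaves unreadable from compound 2 to compound 3.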

Compound 3, dose for half-maximal effect: < 1 mg/kg
Compound 3 ended at the assay's limit; the forecaster's own chance of this, stated with the estimate: 40%; the middle value does not contradict the limit.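

No new step can be read between compound 3 and either compound 1 or compound 2 in this assay, since the values of compound 2 and compound 3 are limits: the limit of < 1 mg/kg in this assay, at which 2 of the 3 values shown sit.

Still open, on these data alone, is how far compound 2 and compound 3 lie from compound 1, and whether 1-methyl-1H-pyrazol-5-yl and 1-methyl-1H-pyrazol-3-yl differ at all.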